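The source may report more compounds than this note shows. Statements on the series, on what has been measured and on what is new or still open speak of the compounds shown alone.

Of the compounds shown here, three sharing one core have been measured in a functional assay on HeLa cells (Homo sapiens) for cytotoxicity; a lower number here means a stronger inhibitor, a higher number a weaker inhibitor: compound 1 `C=CCOc1ccc2c(c1)C(=O)C=CC2=O` gives 27200 nM, compound 2 `CCOc1ccc2c(c1)C(=O)C=CC2=O` gives 25100 nM and compound 3 `O=C1C=CC(=O)c2cc(Oc3ccco3)ccc21` gives 17200 nM. Compound 3 has the smallest number of the three, but this is no real separation, since it stands within the scatter of both others. The next compound, compound 4 `O=C1C=CC(=O)c2cc(Oc3cccs3)ccc21`, carries thiophen-2-yl in place of furan-2-yl on an oxygen on an aromatic ring.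

The measured steps that bear on this change are those that alter the group on that same oxygen or its chain: a 1.1-fold lower number from compound 1 to compound 2 (0.03 log units; within the scatter), a 1.6-fold lower number from compound 1 to compound 3 (0.20 log units; within the scatter) and a 1.5-fold lower number from compound 2 to compound 3 (0.16 log units; within the scatter). All of them stay within the scatter, even the two that bring in the furan-2-yl ring. Among the measured compounds shown here, no measured pair exchanges one five-membered aromatic ring for another, so the data hold no direct precedent for this swap. For the measured compounds named here, with these small steps as the only guide, no step beyond the scatter is expected in this assay. The expected change is a 1.0-fold lower number from compound 3 to compound 4 (0.01 log units; within the scatter). The estimate for compound 4 is 17000 nM, with an expected range from 8500 nM to 34000 nM.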

Compound 4, half-maximal inhibitory concentration: 8860 nM
For compound 4 the middle estimate is 1.9-fold (0.28 log units) above the measured one; measured number inside the range.
By their numbers in this assay, from the lowest: compounds 4, 3, 2 and 1 (each within the scatter of the next, the first and the last beyond it).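

In this assay, the group on this oxygen now gives steps beyond the scatter, both modest (a 2.8-fold lower number from compound 2 to compound 4 (0.45 log units; beyond the scatter) and a 3.1-fold lower number from compound 1 to compound 4 (0.49 log units; beyond the scatter)), whereas the furan-2-yl group of compound 3 stayed within the scatter of both the ethyl and the allyl groups. The direct exchange of one five-membered aromatic ring for the other, with sulfur entering and oxygen leaving and the heavy atom count unchanged, remains within the scatter (a 1.9-fold lower number from compound 3 to compound 4 (0.29 log units; within the scatter)), so thiophen-2-yl separates from the two open chains but not from furan-2-yl. No measurement shown here offers an explanation for these differences.

The compounds shown leave open whether a phenyl or pyridyl ring on the same oxygen would fall in line with the two five-membered rings, and whether the separation from the open chains would also hold against a longer alkyl chain. They also leave open how a chain ending in an amine or a carboxylic acid would read at this position in this assay.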